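The source may report more compounds than this note shows. Statements on the series, on what has been measured and on what is new or still open speak of the compounds shown alone.

The measured compounds:
compound 1, `COc1ccccc1/C=C1\CCC/C(=C\c2cccc(OC)c2OC)C1=O`
compound 2, `COc1ccc(/C=C2\CCC/C(=C\c3cccc(Cl)c3)C2=O)cc1OC`

In a functional assay on SW-620 cells (Homo sapiens) for cytotoxicity, read by MTT assay, with a stated time of 72 h (a higher number here means a weaker inhibitor, a lower number a stronger inhibitor), compound 1 gives > 20000 nM; this is a limit of the assay rather than a number, as recorded in the limit of > 20000 nM in this assay, at which 1 of the 2 values shown sits. In this assay compound 2 gives 5100 nM. Among the two values shown, compound 2 therefore holds the only number, the other being a limit, and nothing more can be said of how the two compounds stand relative to one another. Within the data shown here, no pair of measured compounds differs in a single place, so no step between measured compounds is available.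

Compound 3, `COc1ccc(/C=C2\CCC/C(=C\c3ccc(Cl)cc3Cl)C2=O)cc1OC`, is not yet measured. It differs from compound 2 by 2,4-dichlorophenyl in place of 3-chlorophenyl on a double-bonded chain carbon bound to a double-bonded ring carbon. Among the measured compounds shown here, with no counted step to lean on, the expected step from compound 2 to compound 3 in this assay is a 1.0-fold lower number from compound 2 to compound 3 (0.01 log units; within the scatter), which is judged to lie within the usual scatter, with no clear direction. Compound 3 is accordingly expected to give about 5000 nM, estimated to fall between 2000 nM and 14000 nM.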

Compound 3, half-maximal inhibitory concentration: 10300 nM
Compound 3: middle estimate off by 2.1-fold (0.31 log units), on the low side, within the range that was stated.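

In this assay, replacing 3-chlorophenyl with 2,4-dichlorophenyl on a double-bonded chain carbon bound to a double-bonded ring carbon gives a 2.0-fold higher number from compound 2 to compound 3 (0.31 log units; beyond the scatter). Among these compounds, this is the first comparison that isolates a single place, and it shows that the substitution on this aromatic ring can move the number beyond the scatter, although the step is modest. The direction is toward weaker inhibition, so on this one pair the extra chlorine and altered chlorine pattern of 2,4-dichlorophenyl bring no gain over 3-chlorophenyl.

Compound 1 differs from both of the others in more than one place and carries a limit rather than a number, so it adds nothing to this step: the limit of > 20000 nM in this assay, at which 1 of the 3 values shown sits. Among the compounds shown here, the single step cannot separate the effect of the added chlorine from that of the changed chlorine pattern, and it leaves open how the number would respond to 4-chlorophenyl, or to a group of a different kind on this ring, such as an amine or a carboxylic acid.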